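A few compounds are considered here, and "the series" means these few. Any claim that something is new, unique, unknown or untested is made for them only; others in the source may bear on it.

Measured compounds:
compound 1 `Cc1ccc(NC2=CC(=O)c3nc4n(c3C2=O)[C@H]2OC[C@@H](O)[C@H]2OC4)cc1`, 1420 nM
compound 2 `O=C1C(Nc2cccc(Cl)c2)=CC(=O)c2c1nc1n2[C@H]2OC[C@@H](O)[C@H]2OC1`, 1530 nM
compound 3 `CCCc1ccc(NC2=CC(=O)c3c(nc4n3[C@H]3OC[C@@H](O)[C@H]3OC4)C2=O)cc1`, 1920 nM

In a functional assay on MGC-803 cells (Homo sapiens) for inhibition, read by sulforhodamine B assay (on this read-out lower numbers stand for stronger inhibition and higher numbers for weaker inhibition), compound 1 gives the lowest of the three numbers, although its gaps to compound 2 and compound 3 both lie within the scatter. Within the data shown here, the one step among the measured compounds, a 1.3-fold higher number from compound 2 to compound 3 (0.10 log units; within the scatter), swaps one aryl group for another on the amine nitrogen and shows no change beyond the scatter.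

Compound 4 `O=C1C=C(NC2CCCCC2)C(=O)c2c1nc1n2[C@H]2OC[C@@H](O)[C@H]2OC1` differs from compound 1 by cyclohexyl in place of 4-methylphenyl on an amine nitrogen. Among the measured compounds shown here, no measured step exchanges an aromatic group for a saturated ring at this position, so the three measured values give only a baseline. The account therefore expects a modest step of a 1.8-fold higher number from compound 1 to compound 4 (0.25 log units; within the scatter), estimating compound 4 at 2500 nM in this assay, within a range of 900 nM to 7000 nM.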

Compound 4, half-maximal inhibitory concentration: > 8000 nM
Compound 4: no number, only a limit; the forecaster's own chance of this, stated with the estimate: 10%; middle value at least 3.2-fold (0.50 log units) away from the limit.
By their numbers in this assay, from the lowest: compounds 1, 2 and 3 (each within the scatter of the next). At a limit, above all of these: compound 4.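

In this assay, compound 4 gives > 8000 nM, which is a limit of the assay and not a number. Cyclohexyl in place of 4-methylphenyl on this amine nitrogen brings an at least 5.6-fold higher number from compound 1 to compound 4 (0.75 log units; beyond the scatter), whereas the exchange of one aryl group for another brought a 1.3-fold higher number from compound 2 to compound 3 (0.10 log units; within the scatter). The position thus responds to this change from an aromatic to a saturated ring in a way the aryl exchange did not reveal. Whether this holds for other non-aromatic groups stays open: the compounds shown include no cyclopentyl ring, benzyl group or open alkyl chain on this nitrogen.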